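Shortening the iodoacetamide tether on a nucleotide scaffold

The source may report more compounds than this note shows. Statements on the series, on what has been measured and on what is new or still open speak of the compounds shown alone.

Measured compounds:
compound 1, `CN(CCCCN(C)C(=O)CCCCNc1ncnc2c1ncn2[C@@H]1O[C@H](COP(=O)(O)OP(=O)(O)OP(=O)(O)O)[C@@H](O)[C@H]1O)C(=O)CCCCNC(=O)CI`: 0%
compound 2, `O=C(CI)NCCCCCCCNc1ncnc2c1ncn2[C@@H]1O[C@H](COP(=O)(O)OP(=O)(O)OP(=O)(O)O)[C@@H](O)[C@H]1O`: 30%
compound 3, `O=C(CI)NCCCCCCC(=O)NCCCCCCNc1ncnc2c1ncn2[C@@H]1O[C@H](COP(=O)(O)OP(=O)(O)OP(=O)(O)O)[C@@H](O)[C@H]1O`: 0%

In an assay on isolated protein for inhibition of hexokinase-2 (Rattus norvegicus), with a stated time of 6 h, tested at 10 mM (on this read-out lower numbers stand for less inhibition and higher numbers for more inhibition at the one concentration tested (going by the name of the read-out)), compound 3 gives 0%, level at the digits shown with compound 1, and the two together are the lowest of the three numbers. Compound 2 gives 30%, a number higher than that of compound 3 by an amount beyond the scatter. Compound 4 `O=C(CI)NCCC(=O)NCCCCCCNc1ncnc2c1ncn2[C@@H]1O[C@H](COP(=O)(O)OP(=O)(O)OP(=O)(O)O)[C@@H](O)[C@H]1O` differs from compound 3 in one place: ((iodomethyl)carbonyl)amino in place of 4-(((iodomethyl)carbonyl)amino)butyl on a saturated chain carbon, two bonds along the chain from a carbonyl carbon. Among the measured compounds shown here, no two measured compounds differ in a single place, so no step of that kind is known, and the expectation for compound 4 rests on the three numbers alone. The change leaves compound 4 with a shorter chain than compound 3, between the chain lengths of compound 2 and compound 3. A small step, upward if anything and hardly beyond the scatter, is expected: a number 10 percentage points higher from compound 3 to compound 4 (within the scatter). Compound 4 is estimated to give 10%, with a range from 0% to 35%.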

Compound 4, a percentage reported as inhibition, at one concentration (the size of the read-out at that concentration, not a potency): 0%
The estimate for compound 4 lay 10 percentage points above the measured number, and the stated range covers the measured number.
By their numbers in this assay, from the lowest: compounds 1, 3 and 4 (each within the scatter of the next); then compound 2.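

In this assay, ((iodomethyl)carbonyl)amino in place of 4-(((iodomethyl)carbonyl)amino)butyl on this saturated chain carbon gives no change at the digits printed from compound 3 to compound 4 (within the scatter), so removing this stretch of the tether does not raise the number above that of the longer compound. The step of a number 30 percentage points lower from compound 2 to compound 4 (beyond the scatter) carries a group of 10 heavy atoms in place of a group of 6 heavy atoms, on a saturated chain carbon, six bonds along the chain from a nitrogen on an aromatic ring, and it shows that the shortened amide-containing tether still does not reach the number of compound 2. Nothing available bears on the reason for either step.

On these data alone, whether a longer unbroken alkyl chain would match or exceed compound 2 remains open. So does whether a bromoacetyl group in place of the iodoacetyl end would change the number on any of these tethers.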